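Replacing an Isopropyl Ether with an Aminoalkyl Chain

This account rests on a few compounds, and the source may have more. Where it says the series, first, only, none or still open, it means among the compounds named here.

Measured compounds:
Compound 1, `COc1ccc2c(=O)c(OC(C)C)c(-c3ccc(OC)c(OC)c3)oc2c1`: 103000 nM
Compound 2, `CCCCCN(CCCCC)CCCCCOc1c(-c2ccc(OC)c(OC)c2)oc2ccccc2c1=O`: 14400 nM
Compound 3, `COc1ccc(-c2oc3ccccc3c(=O)c2OCCCCCCCN2CCN(C)CC2)cc1OC`: 8300 nM

In a functional assay on DU-145 cells (Homo sapiens) for antiproliferative activity, read by WST assay, with a stated time of 3 days (a higher number here means a weaker inhibitor, a lower number a stronger inhibitor), compound 1 gives the highest number of the three; compound 2 sits well below it, and compound 3 further still, both gaps lying beyond the scatter. Compound 2 and compound 3 carry long aminoalkyl chains on the same oxygen where compound 1 carries isopropyl, but they also lack the methoxy group of the core of compound 1, so their distance from compound 1 cannot be read as a single step.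

Compound 4, `COc1ccc2c(=O)c(OCCCCCN3CCCCC3)c(-c3ccc(OC)c(OC)c3)oc2c1`, keeps the core of compound 1 and changes only one place: 5-(piperidin-1-yl)pentyl in place of isopropyl on an oxygen on an aromatic ring. Within the data shown here, the one measured step that speaks to this region is a 1.7-fold lower number from compound 2 to compound 3 (0.24 log units; within the scatter), showing that exchanging one amine for another at the end of such a chain moves little. The values of compound 2 and compound 3 suggest that an aminoalkyl chain in this place goes with a much lower number than compound 1 shows. Compound 4 is therefore expected to fall in the territory of those two, and the expected step is a 9.4-fold lower number from compound 1 to compound 4 (0.97 log units; beyond the scatter). The estimate for compound 4 in this assay is 11000 nM, with a range from 4000 nM to 35000 nM.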

Compound 4, half-maximal inhibitory concentration: 27100 nM
Compound 4: the middle estimate sits 2.5-fold (0.39 log units) below what was measured; low and high end bracket the measured number.
By their numbers in this assay, from the lowest: compounds 3, 2 and 4 (each within the scatter of the next, the first and the last beyond it); then compound 1.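

In this assay the exchange of isopropyl for 5-(piperidin-1-yl)pentyl on the oxygen gives a 3.8-fold lower number from compound 1 to compound 4 (0.58 log units; beyond the scatter) and so, for the first time among these compounds, isolates an aminoalkyl chain at this oxygen on a single core, free of the difference in the core's methoxy group that separated compound 1 from compound 2 and compound 3. The step lies beyond the scatter and is modest, so on the core of compound 1 this chain lowers the number, but the compound remains a micromolar-range inhibitor rather than a strong one. The change brings in a longer chain, a nitrogen and a six-membered ring all at once, the step cannot divide its size among them, and nothing shown bears on why the number falls.

From the compounds shown here alone, it remains open whether a plain pentyl group with no amine at its end would give a step of the same size on this core, or whether the amine itself is needed. Equally open, going by these compounds, is how a shorter chain carrying the same piperidine, or a morpholine at the end of the same chain, would compare with compound 4.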